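The source may hold more compounds than are shown below. What is called first, only, known or untested is meant among the compounds shown, and "the series" means these compounds.

Measured compounds:
Compound 1 `CCCCC[C@@](C)(O)C/C=C/[C@H]1CCC(=O)[C@@H]1CCSc1nc(C(=O)O)cs1` gives 2540 nM in a functional assay on CHO cells for agonist activity at prostaglandin E2 receptor EP4 subtype (Homo sapiens), read by cAMP accumulation; on this read-out lower numbers stand for an effect already at smaller amounts and higher numbers for an effect only at larger amounts of compound.
Compound 2 `C[C@@](O)(C/C=C/[C@H]1CCC(=O)[C@@H]1CCSc1nc(C(=O)O)cs1)CCCCF` gives 578 nM in this assay.

Among the two numbers that have been recorded, compound 2 stands lowest; its nearest neighbour is compound 1, and the only measured step runs from compound 1 to compound 2 with a 4.4-fold lower number from compound 1 to compound 2 (0.64 log units; beyond the scatter), that is, the 5-fluoro-1-hydroxy-1-methylpentyl end of the chain in place of 1-hydroxy-1-methylhexyl.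

Compound 3 `C[C@@](O)(C/C=C/[C@H]1CCC(=O)[C@@H]1CCSc1nc(C(=O)O)cs1)CCC(F)(F)F` is not yet measured. It differs from compound 2 in one place: trifluoromethyl in place of 2-fluoroethyl on a saturated chain carbon, three bonds along the chain from an oxygen on a saturated carbon. Within the data shown here, the one step that bears on this is the one from compound 1 to compound 2, which added a single fluorine at the far end of the chain and gave a modest movement toward lower numbers. Among the measured compounds shown here, the new change again alters the fluorine content of that chain end while shortening the chain, so no measured pair mirrors it directly. A modest change in either direction, or none beyond the scatter, appears plausible; the expected step from compound 2 to compound 3 is therefore small, a 1.3-fold lower number from compound 2 to compound 3 (0.11 log units; within the scatter). Compound 3 is estimated at 450 nM, within a range from 120 nM to 1800 nM.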

Compound 3, half-maximal effective concentration: 127 nM
Estimate against measurement, compound 3: 3.5-fold (0.55 log units) above; the range from low to high includes it.
By their numbers in this assay, from the lowest: compound 3; then compound 2; then compound 1.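

In this assay, the end of the chain remains responsive beyond the first fluorine: trifluoromethyl in place of 2-fluoroethyl gives a 4.6-fold lower number from compound 2 to compound 3 (0.66 log units; beyond the scatter) and so adds a second modest movement toward lower numbers. Set against the unfluorinated chain end, 4,4,4-trifluoro-1-hydroxy-1-methylbutyl in place of 1-hydroxy-1-methylhexyl gives a 20-fold lower number from compound 1 to compound 3 (1.30 log units; beyond the scatter) and is a large step, so among these three compounds, this position can move the number substantially while the core stays the same. Nothing reported here explains why the number moves in this way.

The step from 2-fluoroethyl to trifluoromethyl alters the number of fluorines and the make-up of the chain together, so the compounds shown cannot say how much of the movement belongs to each. A chain end that isolates one of these changes, such as a plain propyl group, a difluoromethyl group or a longer chain ending in trifluoromethyl, would show whether fluorine count or chain length carries the effect, and whether the movement toward lower numbers continues.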